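A fluorine added to the phenyl ring of compound 2

The source may report more compounds than this note shows. Statements on the series, on what has been measured and on what is new or still open speak of the compounds shown alone.

Three compounds share a core and were tested in an assay on BaF3 cells for inhibition of proto-oncogene tyrosine-protein kinase receptor Ret variant V804M (Homo sapiens), read by MTT assay, with a stated time of 48 h; on this read-out lower numbers stand for stronger inhibition of growth and higher numbers for weaker inhibition of growth. Compound 1, `Nc1ncnc2c1c(-c1cc(C3CC3)on1)nn2C1CCCCC1`, gives 2000 nM in this assay. Compound 2, `CC(C)n1nc(-c2cc(-c3ccccc3)on2)c2c(N)ncnc21`, gives 4970 nM in this assay, which is the higher of the two numbers shown, with the gap to compound 1 lying beyond the usual scatter. Compound 3, `CC(C)n1nc(/C=N/O)c2c(N)ncnc21`, reaches only the limit of this assay, > 10000 nM, so for it no number is known (the limit of > 10000 nM in this assay, at which 1 of the 3 values shown sits).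

The unmeasured compound 4, `CC(C)n1nc(-c2cc(-c3ccc(F)cc3)on2)c2c(N)ncnc21`, differs from compound 2 in one place: fluoro in place of hydrogen on an aromatic carbon. Fluoro in place of hydrogen on an aromatic carbon, para to a large group, is a small change in size, and nothing among the measured compounds speaks to its effect in this assay. The step from compound 2 is therefore expected to stay within the usual scatter, as a 1.2-fold lower number from compound 2 to compound 4 (0.09 log units; within the scatter). On that basis compound 4 is estimated to give 4000 nM in this assay, within a range from 1500 nM to 12000 nM.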

Compound 4, concentration for 50% growth inhibition: > 10000 nM
Compound 4: a limit, no number; the forecaster's own chance of this, stated with the estimate: 20%; middle value at least 2.5-fold (0.39 log units) away from the limit.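

Until now, nothing showed how this assay responds to a change on the phenyl ring of compound 2, and the change from phenyl to 4-fluorophenyl gives an at least 2.0-fold higher number from compound 2 to compound 4 (0.30 log units; that floor lies within the scatter). Compound 4 stands at a limit of the assay and not at a number, so the step has only a floor and its true size cannot be read. This single fluoro therefore brings no sign of stronger inhibition of growth at this position, and the series now has a second compound at the limit: the limit of > 10000 nM in this assay, at which 2 of the 4 values shown sit.

The compounds shown leave open whether this reading is particular to fluoro or would also hold for another group on the same aromatic carbon, such as a methoxy group or an amine. They also leave open whether fluoro would act the same way on other positions of the phenyl ring.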